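The compounds below may be only part of what the source reports. "The series", "measured", "known", "first", "only" and "open" are said of these compounds alone.

Measured so far in a functional assay on microsomes from liver (Rattus norvegicus, strain Wistar) for inhibition, with a stated time of 15 min; on this read-out lower numbers stand for stronger inhibition and higher numbers for weaker inhibition:
- compound 1 `COc1cc(C2CC(c3cc4ccccc4o3)=NN2C(=O)Nc2ccccc2)ccc1O`: 116000000 nM
- compound 2 `COc1cc(C2CC(c3cc4ccccc4o3)=NN2C(=O)Nc2ccccc2O)ccc1O`: 22000000 nM

Compound 2, at 22000000 nM, holds the lower of the two numbers. Compound 3 `COc1ccc(NC(=O)N2N=C(c3cc4ccccc4o3)CC2c2ccc(O)c(OC)c2)cc1` differs from it by 4-methoxyphenyl in place of 2-hydroxyphenyl on an amide-type nitrogen, with 4-methoxyphenyl in place of 2-hydroxyphenyl on an amide-type nitrogen. Within the data shown here, one measured step bears on this: a 5.3-fold lower number from compound 1 to compound 2 (0.72 log units; beyond the scatter), modest and beyond the scatter, for hydroxy in place of hydrogen on an aromatic carbon. That hydroxy leaves with the change, but no 4-methoxyphenyl has been measured, so a rise of similar size in this assay is only an expectation. The expected step is a 3.2-fold higher number from compound 2 to compound 3 (0.50 log units; beyond the scatter). For compound 3 the estimate is 70000000 nM, with an expected range of 20000000 nM to 240000000 nM.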

Compound 3, half-maximal inhibitory concentration: 29000000 nM
Compound 3: the middle estimate sits 2.4-fold (0.38 log units) above what was measured, within the range that was stated.
By their numbers in this assay, from the lowest: compounds 2 and 3 (each within the scatter of the next); then compound 1.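

In this assay, the change at the amide-type nitrogen from 2-hydroxyphenyl to 4-methoxyphenyl leaves the number within the scatter (a 1.3-fold higher number from compound 2 to compound 3 (0.12 log units; within the scatter)). Against the unsubstituted phenyl, methoxy also lowers the number (a 4.0-fold lower number from compound 1 to compound 3 (0.60 log units; beyond the scatter)), so in this pair of analogues a lower number than compound 1 does not depend on the hydroxy that compound 2 carries. No evidence on hand accounts for this.

Compounds 2 and 3 differ in both the group and its place on the ring, so the contribution of each cannot be separated. On these data alone, how an amine or a carboxylic acid on this ring would read remains open.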